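Moving a fluorine from 3,4-difluorophenyl to 2,4-difluorophenyl

The compounds below may be only part of what the source reports. "The series", "measured", "known", "first", "only" and "open" are said of these compounds alone.

Three compounds with a shared core have values in an ADME assay on MT2 cells (Homo sapiens) for cytotoxicity, read by XTT assay, with a stated time of 4 days; a higher number here means that more compound is tolerated, a lower number that less compound is tolerated. Compound 1 `Cc1nc(C(NC(=O)C(=O)Nc2ccc(Cl)cc2)C2CCCCN2)sc1CO` gives > 108000 nM, which is a limit of the assay and not a number. Compound 2 `Cc1ccc(NC(=O)C(=O)NC(c2nc(C)c(CO)s2)C2CCCCN2)c(F)c1` gives > 109000 nM, which is also a limit. Compound 3 `Cc1nc(C(NC(=O)C(=O)Nc2ccc(F)c(F)c2)C2CCCCN2)sc1CO` gives > 87000 nM, again a limit, so it has no exact position on this scale, and neither do the other two.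

Compound 4 `Cc1nc(C(NC(=O)C(=O)Nc2ccc(F)cc2F)C2CCCCN2)sc1CO` differs from compound 3 as follows: 2,4-difluorophenyl in place of 3,4-difluorophenyl on an amide-type nitrogen. It carries 2,4-difluorophenyl in place of 3,4-difluorophenyl on an amide-type nitrogen.

Three measured exchanges at that same nitrogen bear on this change: a step that the two limits leave unreadable from compound 1 to compound 2, a step that the two limits leave unreadable from compound 1 to compound 3 and a step that the two limits leave unreadable from compound 2 to compound 3. None of them has a readable size. The closest guide is compound 2, with its 2-fluoro-4-methylphenyl group, at > 109000 nM, which is a limit. No step beyond the usual scatter is therefore expected in this assay, and no direction can be assigned. The estimate is a step that the limit leaves unreadable from compound 3 to compound 4. Compound 4 is expected at 100000 nM, with an estimated range of 50000 nM to 180000 nM, and it will probably be reported only as a limit.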

Compound 4, half-maximal cytotoxic concentration: > 110000 nM
Compound 4 gave a limit, no number; the forecaster's own chance of this, stated with the estimate: 85%; at least 1.1-fold (0.04 log units) between middle value and limit.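

In this assay compound 4 gives > 110000 nM, which is a limit of the assay and not a number. Within the data shown here, compound 1, compound 2 and compound 3 also stand at limits, so no step between compound 4 and any of them can be read. The compounds shown leave open whether changing the aryl group on the amide-type nitrogen alters the half-maximal cytotoxic concentration at all.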